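The compounds below may be only part of what the source reports. "The series", "measured", "known", "first", "only" and "open" are said of these compounds alone.

Measured so far:
compound 1 `O=C1N=C(N2N=C(c3ccccc3)CC2c2ccccc2O)S/C1=C1/C(=O)Nc2ccccc21` — 48800 nM
compound 2 `O=C1N=C(N2N=C(c3ccccc3)CC2c2ccccc2O)S/C1=C1/C(=O)Nc2ccc(Br)cc21` — 1050 nM

In a functional assay on cells (Leukemia cell, Homo sapiens) for cytotoxicity, read by sulforhodamine B assay, with a stated time of 48 h (a lower number here means a stronger inhibitor of growth, a higher number a weaker inhibitor of growth), compound 1 gives 48800 nM, the highest of the two numbers; the nearest is compound 2, which gives 1050 nM. Within the data shown here, the one measured step, a 46-fold lower number from compound 1 to compound 2 (1.67 log units; beyond the scatter), comes from a bromo in place of hydrogen on an aromatic carbon of the indolinone part of the shared core.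

Compound 3 `COc1ccc(C2CC(c3ccccc3)=NN2C2=NC(=O)/C(=C3\C(=O)Nc4ccccc43)S2)cc1` differs from compound 1 elsewhere: 4-methoxyphenyl in place of 2-hydroxyphenyl on a saturated ring carbon. Among the measured compounds shown here, no measured step touches this ring, so the change from compound 1 to compound 2 bears on it only as a sign that this core can shift strongly in this assay. For the hydroxy-to-methoxy exchange itself nothing measured is available, and so no step beyond the scatter is expected in either direction. Compound 3 is therefore estimated at 40000 nM, with a range from 8000 nM to 150000 nM, a step of a 1.2-fold lower number from compound 1 to compound 3 (0.09 log units; within the scatter) that is expected to stay within the scatter.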

Compound 3, concentration for total growth inhibition: 20800 nM
For compound 3 the middle estimate is 1.9-fold (0.28 log units) above the measured one, within the range that was stated.
By their numbers in this assay, from the lowest: compound 2; then compound 3; then compound 1.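

In this assay the saturated ring carbon of the shared core turns out to be a place where the number can move: 4-methoxyphenyl in place of 2-hydroxyphenyl gives a 2.3-fold lower number from compound 1 to compound 3 (0.37 log units; beyond the scatter) and so lies beyond the scatter, though it is a modest step beside the large one from the bromo group. The hydrogen-bond donor of 2-hydroxyphenyl is thus not required for the growth inhibition seen with compound 1, since compound 3 has none in this group and still gives a somewhat lower number. The two groups differ both in the oxygen-bearing group and in where it sits on the phenyl ring, and this single step cannot separate the two, nor can any measured property explain it.

The compounds shown leave open how 4-hydroxyphenyl or 2-methoxyphenyl would stand at this carbon, and whether an amine on the phenyl ring would move the number further. They also leave open whether bromo and 4-methoxyphenyl together would add up.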